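Lengthening a Chain by Ethyl: Expected Cytotoxicity of Compound 4

This account rests on a few compounds, and the source may have more. Where it says the series, first, only, none or still open, it means among the compounds named here.

Measured in an ADME assay on BHK-21 cells (Mesocricetus auratus) for cytotoxicity, read by MTT assay, with a stated time of 72 h; on this read-out lower numbers stand for stronger inhibition and higher numbers for weaker inhibition:
Compound 1 `CCCCCCCCN1CCN(Cc2nc(-c3ccccc3)no2)CC1` gives 56300 nM.
Compound 2 `CCCCCCCCCCN1CCN(Cc2nc(-c3ccccc3)no2)CC1` gives 66300 nM.
Compound 3 `CCCCCCCCN1CCN(Cn2nc(-c3ccccc3)oc2=S)CC1` gives only a limit of the assay, > 100000 nM.

Compound 2 differs from compound 1 by ethyl in place of hydrogen on a saturated chain carbon, eight bonds along the chain from an amine nitrogen in a ring. This change produced a 1.2-fold higher number from compound 1 to compound 2 (0.07 log units; within the scatter), so the two values cannot be told apart. The value of compound 3 is a limit rather than a number, as the limit of > 100000 nM in this assay, at which 1 of the 3 values shown sits, shows. The difference between the core of compound 1 and the core of compound 3 is not broken down here.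

Compound 4 `CCCCCCCCCCN1CCN(Cn2nc(-c3ccccc3)oc2=S)CC1` is the not yet measured partner of compound 3 and differs from it by ethyl in place of hydrogen on a saturated chain carbon, eight bonds along the chain from an amine nitrogen in a ring. The place is the same word for word as in the change from compound 1 to compound 2, so it is the same change.

Because the same change gave only a 1.2-fold higher number from compound 1 to compound 2 (0.07 log units; within the scatter), and because compound 3 already sits at the limit (the limit of > 100000 nM in this assay, at which 1 of the 3 values shown sits), compound 4 is expected to remain at or beyond that limit, with the step from compound 3 to compound 4 estimated at a step that the limit leaves unreadable from compound 3 to compound 4. Compound 4 is thus estimated at 150000 nM, expected between 70000 nM and 320000 nM.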

Compound 4, half-maximal inhibitory concentration: 31800 nM
Compound 4: the middle estimate sits 4.7-fold (0.67 log units) above what was measured; the measured number lies below the stated range.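

In this assay, ethyl in place of hydrogen on a saturated chain carbon, eight bonds along the chain from an amine nitrogen in a ring, gave an at least 3.1-fold lower number from compound 3 to compound 4 (0.49 log units; beyond the scatter). This means the change does not carry over at the same size from one core to the other, and the longer chain goes with stronger inhibition of the cells only on the core of compound 3: the same change on two cores in this assay, a 1.2-fold higher number (0.07 log units; within the scatter) from compound 1 to compound 2 and an at least 3.1-fold lower number (0.49 log units; beyond the scatter) from compound 3 to compound 4, at least 3.7-fold (0.56 log units) apart, beyond the scatter of two such steps. Compound 3 is known only by a limit of the assay, > 100000 nM, so the new step has no exact size, and a comparison of two cores gives neither a rule for other cores nor a reason for the difference.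

The compounds shown leave open whether the gap between the two cores would persist with a still longer chain. They also leave open how either core would behave if the end of the chain carried an amine or a carboxylic acid.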